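From Nitro to Amino at the Limit of the Assay

The source may hold more compounds than are shown below. What is called first, only, known or untested is meant among the compounds shown, and "the series" means these compounds.

In a functional assay on SK-MEL-28 cells (Homo sapiens) for inhibition (a lower number here means a stronger inhibitor, a higher number a weaker inhibitor), compound 1 `COc1ccc(/C=C/c2ccc3ccccc3c2)cc1[N+](=O)[O-]` gives > 5000 nM, which is a limit of the assay. Compound 2 `COc1ccc(/C=C\c2ccc3ccccc3c2)cc1[N+](=O)[O-]` differs from compound 1 only in the configuration of its double bond. Compound 2 gives > 20000 nM, which is also a limit. Among the measured compounds shown here, the one measured step, a step that the two limits leave unreadable from compound 1 to compound 2, has no readable size and does not touch the nitro group. Compound 3 `COc1ccc(/C=C\c2ccc3ccccc3c2)cc1N` carries amino in place of nitro on an aromatic carbon. For the measured compounds named here, no measured step therefore sizes this change, and the expectation is loose. Since compound 2 sits at a limit, only a move towards stronger inhibition could be seen. The expected change is an at least 10-fold lower number from compound 2 to compound 3 (1.00 log units; beyond the scatter). Compound 3 is estimated at 2000 nM, with an expected range of 200 nM to 20000 nM.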

Compound 3, half-maximal inhibitory concentration: > 20000 nM
Compound 3: no number, only a limit (the forecaster's own chance of this, stated with the estimate: 30%); at least 10-fold (1.00 log units) between middle value and limit.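

Compound 3 gives > 20000 nM, which is a limit and not a number. Among the compounds shown here, with compound 2 also at a limit, no step from compound 2 to compound 3 can be read. The compounds shown leave open whether amino in place of nitro changes inhibition at all.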